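Chloro for Methoxy on the Amino-Linked Ring

The source may hold more compounds than are shown below. What is called first, only, known or untested is meant among the compounds shown, and "the series" means these compounds.

Measured compounds in a functional assay on PC-3 cells (Homo sapiens) for cytotoxicity, read by MTT assay, with a stated time of 72 h; on this read-out higher numbers stand for weaker inhibition and lower numbers for stronger inhibition:
Compound 1, `COc1ccc(Nc2nc3ccccc3nc2S(=O)(=O)c2ccccc2)cc1`: 1510 nM
Compound 2, `COc1ccc(Nc2nc3ccccc3nc2S(=O)(=O)c2ccc(OC)cc2)cc1`: 8710 nM

Compound 2 gives the higher of the two numbers in this assay, so of the pair it is the weaker inhibitor. Within the data shown here, its only neighbour is compound 1, and the one measured step between them, a 5.8-fold higher number from compound 1 to compound 2 (0.76 log units; beyond the scatter), came with a methoxy in place of hydrogen on an aromatic carbon.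

Compound 3, `COc1ccc(S(=O)(=O)c2nc3ccccc3nc2Nc2ccc(Cl)cc2)cc1`, differs from compound 2 by chloro in place of methoxy on an aromatic carbon. In plain words a chloro stands where a methoxy stood, on an aromatic carbon para to a large group, so that the (4-methoxyphenyl)amino group of compound 2 becomes a (4-chlorophenyl)amino group.

Among the measured compounds shown here, no measured step makes this same swap. The step of a 5.8-fold higher number from compound 1 to compound 2 (0.76 log units; beyond the scatter) concerns a methoxy added at a different place and therefore only shows that a methoxy can move the number; it does not show what replacing one by chloro does here. Any expectation must stay broad. Compound 3 is estimated at about 6000 nM, within a range from 1800 nM to 20000 nM. That estimate means a step of a 1.5-fold lower number from compound 2 to compound 3 (0.16 log units; within the scatter), small and possibly not beyond the scatter.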

Compound 3, half-maximal inhibitory concentration: 31800 nM
Compound 3: middle estimate off by 5.3-fold (0.72 log units), on the low side, outside the stated range (above it).
By their numbers in this assay, from the lowest: compound 1; then compound 2; then compound 3.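

In this assay, the change from (4-methoxyphenyl)amino to (4-chlorophenyl)amino gives a 3.7-fold higher number from compound 2 to compound 3 (0.56 log units; beyond the scatter) and so weakens inhibition, which shows that the group on this ring can alter the result. Among these compounds, the earlier step, a 5.8-fold higher number from compound 1 to compound 2 (0.76 log units; beyond the scatter), concerned a methoxy at a different place and could not show this, so compound 3 supplies the first measured information on this position and on this exchange of methoxy for chloro. The comparison also shows that, with the rest of compound 2 held constant, a single chloro in place of a methoxy is enough to produce a change beyond the usual scatter, although no evidence at hand explains that change.

A single exchange cannot tell whether methoxy favours inhibition here or chloro disfavours it, and a plain hydrogen at the same place would be the natural reference point for separating those two readings. As far as these compounds go, how a fluoro, an amine or a carboxylic acid at this position would compare with methoxy and chloro also remains open, as does whether the same exchange would have a similar effect on the core of compound 1.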